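From compound 3 to compound 4

The source may hold more compounds than are shown below. What is called first, only, known or untested is meant among the compounds shown, and "the series" means these compounds.

Three compounds measured in a functional assay on HEK293 cells (Homo sapiens) for cytotoxicity (a higher number here means that more compound is tolerated, a lower number that less compound is tolerated), each value a limit:
- compound 1 (`COc1ccc([C@H]2CC(=O)N(C(=O)c3ccccc3)C2)cc1OC1CCCC1`) gives > 10000 nM
- compound 2 (`COc1ccc([C@H]2CC(=O)N(c3ccc(N)cc3)C2)cc1OC1CCCC1`) gives > 10000 nM
- compound 3 (`COc1ccc([C@H]2CC(=O)N(c3cccc(C)c3)C2)cc1OC1CCCC1`) gives > 10000 nM

Compound 3 stands at the limit of > 10000 nM in this assay, at which 3 of the 3 values shown sit, and so has a limit, not a number. Compound 4 (`COc1ccc([C@H]2CC(=O)N(c3ccc(C(F)(F)F)cc3)C2)cc1OC1CCCC1`) carries 4-(trifluoromethyl)phenyl in place of 3-methylphenyl on an amide-type nitrogen in a ring. Three measured changes at that nitrogen bear on this: a step that the two limits leave unreadable from compound 1 to compound 2, a step that the two limits leave unreadable from compound 1 to compound 3 and a step that the two limits leave unreadable from compound 2 to compound 3, so none offers a size. No step beyond the scatter is expected in this assay, and no direction can be expected either. The estimated step is a step that the limit leaves unreadable from compound 3 to compound 4 and rests on these limits alone. For compound 4 the estimate is 15000 nM, with an expected range from 7000 nM to 30000 nM and a reported limit the likeliest outcome.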

Compound 4, half-maximal cytotoxic concentration: > 10000 nM
Compound 4 gave a limit, no number; the forecaster's own chance of this, stated with the estimate: 85%; the middle value does not contradict the limit.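

No step from compound 1, compound 2 or compound 3 to compound 4 can be read in this assay, as all four compounds share one limit: the limit of > 10000 nM in this assay, at which 4 of the 4 values shown sit.

The compounds shown leave open whether any change on that nitrogen alters cytotoxicity at all.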